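Benzyl-substituted chlorinated purine series: cytotoxicity notes

This account rests on a few compounds, and the source may have more. Where it says the series, first, only, none or still open, it means among the compounds named here.

Measured so far:
- compound 1, `ClCc1ccc(Cn2cnc3c(Cl)ncnc32)cc1`: 2450 nM
- compound 2, `ClCc1cccc(Cn2cnc3c(Cl)ncnc32)c1`: 3090 nM

In a functional assay on HCT-116 cells (Homo sapiens) for cytotoxicity, read by sulforhodamine B assay, with a stated time of 48 h (a lower number here means a stronger inhibitor of growth, a higher number a weaker inhibitor of growth), compound 1 gives 2450 nM, the lowest of the two numbers in hand. Compound 2 sits within the scatter of compound 1, so the two cannot be ordered on these data.

The next compound, compound 3, `ClCc1ccc(Cn2cnc3c(Cl)nc(Cl)nc32)cc1`, has not yet been measured. It differs from compound 1 by chloro in place of hydrogen on an aromatic carbon; the newcomer sits between two ring nitrogen atoms of the shared core, meta to the existing chloro group. Going by the values given here, no measured pair shows this change, so no step for it is known. The expectation for this assay is a small step, inside or just beyond the scatter, with direction uncertain. Compound 3 is estimated at 1800 nM, range 600 nM to 5000 nM, which would mean an expected step of a 1.4-fold lower number from compound 1 to compound 3 (0.13 log units; within the scatter).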

Compound 3, concentration for total growth inhibition: 3630 nM
Compound 3: middle estimate off by 2.0-fold (0.30 log units), on the low side; low and high end bracket the measured number.
By their numbers in this assay, from the lowest: compounds 1, 2 and 3 (each within the scatter of the next).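

Chloro in place of hydrogen on the aromatic carbon between two ring nitrogen atoms of the shared core gives, in this assay, a 1.5-fold higher number from compound 1 to compound 3 (0.17 log units; within the scatter), a step within the scatter, so compound 1 and compound 3 cannot be ordered. Compound 1 and compound 2 both carry hydrogen at this position, so they said nothing about it; compound 3 shows that a second chloro group, meta to the existing chloro group, is compatible with a number in the same range. No measurement at hand bears on why this is so.

A single step with one group leaves open whether an amine, a methoxy group or a longer chain at this position would also stay within the scatter of compound 1. As far as these compounds go, whether chloro here would behave alike on compound 2 also remains open.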